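The source may report more compounds than this note shows. Statements on the series, on what has been measured and on what is new or still open speak of the compounds shown alone.

Going by the values given here, in a functional assay on Daoy cells (Homo sapiens) for antiproliferative activity, read by trypan blue exclusion and crystal violet staining, with a stated time of 72 h (on this read-out lower numbers stand for stronger inhibition and higher numbers for weaker inhibition), three compounds have numbers so far. Compound 1 `COc1ccc(C(NC(C)=O)c2cc(Cl)c3cccnc3c2O)cc1OC` gives 210 nM, and compound 3 `O=C(NCc1ccc2c(OCc3ccccc3)ccnc2c1O)C1CCCCC1` gives 260 nM. Compound 2 `CCCC(=O)NC(c1ccc(C)cc1)c1cc(Cl)c2cccnc2c1O` gives 100 nM, the lowest of the three, and its gap to each of the other two lies beyond the usual scatter of repeat measurements.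

Compound 4 `CCCC(=O)NC(c1ccccc1Cl)c1cc(Cl)c2cccnc2c1O` has not yet been measured. It differs from compound 2 in one place: 2-chlorophenyl in place of 4-methylphenyl on a saturated chain carbon bound to an amide-type nitrogen and an aromatic carbon. Put simply, 2-chlorophenyl stands in place of 4-methylphenyl on a saturated chain carbon bound to an amide-type nitrogen and an aromatic carbon.

Among the compounds with values here, no two measured compounds differ in just one place, so the data offer no direct guide to this swap. Compound 2, at 100 nM, already has the lowest number, so a small move towards a higher number seems somewhat more likely than a move lower. The expected change, a 1.4-fold higher number from compound 2 to compound 4 (0.15 log units; within the scatter), is no larger than the scatter. For compound 4 the estimate is 140 nM, with an expected range of 50 nM to 380 nM.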

Compound 4, half-maximal inhibitory concentration: 100 nM
Compound 4: middle estimate off by 1.4-fold (0.15 log units), on the high side; the range from low to high includes it.
By their numbers in this assay, from the lowest: compounds 2 and 4 (each within the scatter of the next); then compounds 1 and 3 (each within the scatter of the next).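

In this assay, putting 2-chlorophenyl in place of 4-methylphenyl on the saturated chain carbon bound to an amide-type nitrogen and an aromatic carbon gives no change at the digits printed from compound 2 to compound 4 (within the scatter) for this pair. This is the only pair shown that differs in one place, and it gives the first direct reading of this position: here, one substituted phenyl ring can replace another, with the same count of heavy atoms, without moving the number beyond the scatter. No measured evidence bears on why the two groups read alike.

From the compounds shown here alone, whether this position would also accept a group of another kind, such as an amine or a carboxylic acid, stays open. So does the reading for 4-chlorophenyl or 2-methylphenyl, as this swap changed both the substituent and its place on the ring.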